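This account rests on a few compounds, and the source may have more. Where it says the series, first, only, none or still open, it means among the compounds named here.

Measured in a functional assay on CCRF-CEM cells (Homo sapiens) for cytotoxicity, read by MTT assay, with a stated time of 72 h; a lower number here means that less compound is tolerated, a higher number that more compound is tolerated:
compound 1 `CCCOC(=O)Nc1ccc([Se]C#N)cc1` gives 68800 nM;
compound 2 `N#C[Se]c1ccc(NC(=O)Oc2ccccc2)cc1` gives 73200 nM.

Compound 2 and compound 1 cannot be told apart in this assay, the step of a 1.1-fold higher number from compound 1 to compound 2 (0.03 log units; within the scatter) lying within the scatter. Compound 3 `COc1ccc(OC(=O)Nc2ccc([Se]C#N)cc2)cc1` differs from compound 2 by methoxy in place of hydrogen on an aromatic carbon. Among the compounds with values here, no measured step shows a methoxy entering on an aromatic carbon; the only step available concerned the group on the oxygen next to the carbonyl and stayed within the scatter. Within the data shown here, because the one step of a 1.1-fold higher number from compound 1 to compound 2 (0.03 log units; within the scatter) gave no movement, nothing beyond the scatter is expected here. The expected step is a 1.0-fold lower number from compound 2 to compound 3 (0.00 log units; within the scatter). The estimate for compound 3 in this assay is 73000 nM, with a range from 35000 nM to 150000 nM.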

Compound 3, concentration lethal to 50% of the cells: 70000 nM
Estimate against measurement, compound 3: 1.0-fold (0.02 log units) above; low and high end bracket the measured number.
By their numbers in this assay, from the lowest: compounds 1, 3 and 2 (each within the scatter of the next).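

In this assay, within the data shown here, methoxy in place of hydrogen on this aromatic carbon, para to a large group, gives a 1.0-fold lower number from compound 2 to compound 3 (0.02 log units; within the scatter) and so shows for the first time how a substituent on the ring itself behaves. At this position, compound 3 cannot be told apart from compound 2 despite the added methoxy. No evidence is available to account for this result. From the compounds shown here alone, whether an amine or a carboxylic acid on the same carbon would move the number beyond the scatter stays open. So does the effect of a longer chain such as butoxy there.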